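The source may hold more compounds than are shown below. What is called first, only, known or untested is meant among the compounds shown, and "the series" means these compounds.

In an ADME assay on HEK293 cells (Homo sapiens) for cytotoxicity, read by MTT assay, with a stated time of 48 h (a lower number here means a stronger inhibitor, a higher number a weaker inhibitor), compound 1 `CN(C)CCn1c(N)c(-c2nc3ccccc3n2C)c2nc(C#N)c(C#N)nc21` gives > 50000 nM, which is a limit and not a number. Compound 2 `CCN(CC)CCn1c(N)c(-c2nc3ccccc3n2C)c2nc(C#N)c(C#N)nc21` gives 25400 nM, the higher of the two actual numbers in the series. Compound 3 `CN(C)CCCCn1c(N)c(-c2nc3ccccc3n2C)c2nc(C#N)c(C#N)nc21` gives 3870 nM, and the gap between these two is a 6.6-fold lower number from compound 2 to compound 3 (0.82 log units; beyond the scatter).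

Compound 4 `CCN(CC)CCn1c(N)c(-c2nc3cc(Cl)ccc3[nH]2)c2nc(C#N)c(C#N)nc21` keeps the 2-(diethylamino)ethyl group of compound 2 but carries 5-chloro-1H-benzimidazol-2-yl in place of 1-methyl-1H-benzimidazol-2-yl on an aromatic carbon. The measured steps all alter the chain instead: an at least 1.9-fold lower number from compound 1 to compound 2 (0.29 log units; that floor lies within the scatter), and an at least 12-fold lower number from compound 1 to compound 3 (1.11 log units; beyond the scatter). None touches this aromatic group, so they bear on the change only as a rough guide to size, and the nearest guide is the modest 6.6-fold lower number from compound 2 to compound 3 (0.82 log units; beyond the scatter). On that basis, the change is expected to give a modest move towards a lower number in this assay, estimated as a 2.5-fold lower number from compound 2 to compound 4 (0.40 log units; beyond the scatter). The expected value for compound 4 is 10000 nM, within an estimated range of 2500 nM to 40000 nM.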

Compound 4, half-maximal inhibitory concentration: > 50000 nM
Compound 4 ended at the assay's limit; the forecaster's own chance of this, stated with the estimate: 15%; middle value at least 5.0-fold (0.69 log units) from the limit.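

Within the data shown here, replacing 1-methyl-1H-benzimidazol-2-yl with 5-chloro-1H-benzimidazol-2-yl gives the first step at this aromatic carbon, all earlier steps having altered the chain: an at least 1.9-fold higher number from compound 2 to compound 4 (0.29 log units; that floor lies within the scatter). The swap therefore brings no lower number, although that floor alone does not establish a real rise. In this assay compound 4 gives > 50000 nM, which is a limit and not a number, and the true size of the step stays unread because the reading stops there: the limit of > 50000 nM in this assay, at which 2 of the 4 values shown sit.

The swap removes the 1-methyl group and adds a chlorine together, and the compounds shown do not separate these two changes, which the unsubstituted 1H-benzimidazol-2-yl group could begin to do. Also open, on these data alone, is how the 5-chloro-1H-benzimidazol-2-yl group behaves with the 4-(dimethylamino)butyl chain of compound 3.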